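Ester versus acid on a chloropyrimidine thioether series

The compounds below may be only part of what the source reports. "The series", "measured", "known", "first", "only" and "open" are said of these compounds alone.

Compound 1 `CCCCCCC(Sc1nc(Cl)cc(Oc2ccc3ncccc3c2)n1)C(=O)O` gives 91.4% in an assay for inhibition of Polyunsaturated fatty acid 5-lipoxygenase (Homo sapiens), tested at 1 uM; a lower number here means a stronger effect, a higher number a weaker effect of the compound at the concentration tested. Compound 2 `CCCCCCC(Sc1nc(Cl)cc(Oc2ccc3ncccc3c2)n1)C(=O)OCC` gives 67.4% in this assay. The change between the two is ethyl in place of hydrogen on an oxygen next to a carbonyl group, and the step it made is a number 24 percentage points lower from compound 1 to compound 2 (beyond the scatter). Compound 3 `O=C(O)CSc1nc(Cl)cc(Nc2cccc3c2CCC3)n1` carries a different core, and the difference between the two cores is not broken down here; in this assay compound 3 gives 71.1%, which is near the number of compound 2 and further from the number of compound 1.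

Compound 4 `CCOC(=O)CSc1nc(Cl)cc(Nc2cccc3c2CCC3)n1` is not yet measured in this assay. It differs from compound 3 by ethyl in place of hydrogen on an oxygen next to a carbonyl group, the same change as that from compound 1 to compound 2, at the same place on an oxygen next to a carbonyl group. Within the data shown here, on the expectation that the step repeats, a step of about a number 21.1 percentage points lower from compound 3 to compound 4 (beyond the scatter) is estimated, resting on the single earlier step of a number 24 percentage points lower from compound 1 to compound 2 (beyond the scatter) and on the value of compound 3, 71.1%. Among the measured compounds shown here, compound 4 is therefore expected to give about 50% in this assay, with a range from 30% to 72%, a wide range because only one step of this kind a number 24 percentage points lower from compound 1 to compound 2 (beyond the scatter) is known and on a different core.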

Compound 4, a percentage reported as activity, at one concentration (the size of the read-out at that concentration, not a potency): 65.2%
The estimate for compound 4 lay 15.2 percentage points below the measured number, and the stated range covers the measured number.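

On the core of compound 3, ethyl in place of hydrogen on an oxygen next to a carbonyl group makes a step of a number 5.9 percentage points lower from compound 3 to compound 4 (within the scatter) in this assay. Among these compounds, the size of this step therefore does not carry from one core to the other, and a step read on one core is a poor guide to the other: the same change on two cores in this assay, a number 24 percentage points lower (beyond the scatter) from compound 1 to compound 2 and a number 5.9 percentage points lower (within the scatter) from compound 3 to compound 4, 18.1 percentage points apart, beyond the scatter of two such steps The two pairs differ from each other in more than one place, so these data do not show which part of the core goes with the difference in step size, and with only two pairs they give no general rule for this change.

From the compounds shown here alone, it remains open how an amide in place of the carboxylic acid, or a longer chain in place of ethyl on the same oxygen, would behave on either core. Also open, going by these compounds, is whether the step on each core would hold up in a full concentration series rather than at a single concentration.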